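Trimming a Methyl from the Urea Side Chain

This account rests on a few compounds, and the source may have more. Where it says the series, first, only, none or still open, it means among the compounds named here.

Measured compounds in an assay on isolated protein for inhibition of histamine H2 receptor (Cavia porcellus); on this read-out higher numbers stand for weaker binding and lower numbers for tighter binding:
compound 1 `CC(C)CNC(=O)NCCCOc1cccc(CN2CCCCC2)c1` gives 170 nM
compound 2 `O=C(NCCCOc1cccc(CN2CCCCC2)c1)Nc1ccc(C(F)(F)F)cc1` gives 1700 nM
compound 3 `CCC(C)NC(=O)NCCCOc1cccc(CN2CCCCC2)c1` gives 95.5 nM

Among these three, compound 3 carries the lowest number, but the step of a 1.8-fold lower number from compound 1 to compound 3 (0.25 log units; within the scatter) is within the scatter, so compound 1 and compound 3 cannot be ranked. Against compound 2 the gap is clear: an 18-fold lower number from compound 2 to compound 3 (1.25 log units; beyond the scatter). Compound 4 `CCCNC(=O)NCCCOc1cccc(CN2CCCCC2)c1` is the next step. Its change is hydrogen in place of methyl on a saturated chain carbon bound to an amide-type nitrogen and a saturated chain carbon, so a small alkyl group on the urea nitrogen is shortened by one carbon.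

Two kinds of step bear on this. Swapping one small alkyl for another gave a 1.8-fold lower number from compound 1 to compound 3 (0.25 log units; within the scatter), within the scatter. Replacing an alkyl with a 4-(trifluoromethyl)phenyl group gave a 10-fold higher number from compound 1 to compound 2 (1.00 log units; beyond the scatter), a modest worsening. The move to compound 4 stays within the small-alkyl family and is far less drastic than the aryl swap, so on this assay no step beyond the scatter is expected, perhaps a slight rise as the group shrinks. The expected step is a 1.6-fold higher number from compound 3 to compound 4 (0.20 log units; within the scatter). For compound 4 the estimate is 150 nM, with a range from 60 nM to 400 nM.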

Compound 4, dissociation constant: 97.7 nM
Compound 4: middle estimate off by 1.5-fold (0.19 log units), on the high side; the measured number falls inside the stated range.
By their numbers in this assay, from the lowest: compounds 3, 4 and 1 (each within the scatter of the next); then compound 2.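

In this assay, taking the methyl off the sec-butyl group to leave propyl gives two compounds that cannot be told apart (a 1.0-fold higher number from compound 3 to compound 4 (0.01 log units; within the scatter)), so at this saturated chain carbon bound to the amide-type nitrogen, the methyl makes no readable difference to binding. Compound 4 also cannot be separated from the isobutyl compound (a 1.7-fold lower number from compound 1 to compound 4 (0.24 log units; within the scatter)), which means the three small alkyl groups on the urea nitrogen now form a single cluster, with the straight propyl chain sitting in it alongside the two branched chains, while the 4-(trifluoromethyl)phenyl compound stands clearly apart (a 17-fold lower number from compound 2 to compound 4 (1.24 log units; beyond the scatter)). Nothing available gives a reason for this flat response to the methyl or for the gap to the aryl compound.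

The compounds shown leave open how far the alkyl group can shrink or grow before the number moves beyond the scatter, as with an ethyl or methyl group on one side and a butyl or longer chain on the other. They also leave open whether a plain phenyl, a cyclohexyl ring, or a chain ending in an amine or a carboxylic acid would stay with the alkyl cluster or fall nearer compound 2.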